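A few compounds are considered here, and "the series" means these few. Any claim that something is new, unique, unknown or untested is made for them only; others in the source may bear on it.

In an assay on HEK293 cells with Neuronal acetylcholine receptor; alpha4/beta2 (Homo sapiens) as the target, read by FLIPR and calcium flux (on this read-out lower numbers stand for smaller maximal responses and higher numbers for larger maximal responses), compound 1, with the structure `C/C=C\Oc1cncc(N2CCCNCC2)c1`, gives 45%. Within the data shown here, the only other compound measured here is compound 2, `Oc1cc(N2CCCNCC2)cnc1I`, which in this assay reaches 104%. Compound 1 therefore stands lowest of the two numbers shown, and the value of compound 2 lies above it by more than the usual scatter of repeated measurements. Among the measured compounds shown here, no two measured compounds differ in just one place, so no single structural step has yet been tied to a change in the largest response reached.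

Compound 3, `NC(=O)c1cncc(N2CCCNCC2)c1`, is the compound still to be measured. It differs from compound 1 in the following way:

a group of 3 heavy atoms (1 carbon, 1 nitrogen, 1 oxygen; no ring) in place of a group of 4 heavy atoms (3 carbon, 1 oxygen; no ring), on an aromatic carbon

For the measured compounds named here, nothing measured so far points to the direction of this change, since compound 2 differs from compound 1 in more than one place. The step of a number 25 percentage points higher from compound 1 to compound 3 (beyond the scatter) is the change expected here, a moderate rise rather than none beyond the scatter. Compound 3 is expected to give 70% in this assay, most likely between 40% and 100%.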

Compound 3, largest response reached (reported as efficacy), in percent of the reference or control that the assay uses: 56%
Compound 3: middle estimate off by 14 percentage points, on the high side; measured number inside the range.
By their numbers in this assay, from the lowest: compound 1; then compound 3; then compound 2.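

In this assay, placing carbamoyl in the spot held by the group of 4 heavy atoms, on an aromatic carbon two atoms from the ring nitrogen, gives a number 11 percentage points higher from compound 1 to compound 3 (beyond the scatter). Among these compounds, this is the first change in a single place, and it shows that the group on this carbon can shift the largest response, though only by a modest step. The entering carbamoyl carries 1 hydrogen-bond donor and the leaving group carries 0, but no measurement here connects that count, or any other feature of the two groups, to the rise.

Carbamoyl and the leaving group differ in several features at once, so this one step cannot show which of them matters; a nitrile, a carboxylic acid, an amine or a longer chain on the same carbon would be needed to separate them. Going by these compounds, compound 2 differs from the other two compounds in more than one place, so how far the response could climb through changes on this carbon alone also remains open.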